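The source may report more compounds than this note shows. Statements on the series, on what has been measured and on what is new or still open speak of the compounds shown alone.

Compound 1 `COc1ccc(/C=C/c2cc(OC)cc(OC)c2/C=C/C(=O)c2ccc(Cl)c(Cl)c2)cc1` gives 5.9 ug/mL in a functional assay on A549 cells (Homo sapiens) for antiproliferative activity, read by MTT assay, with a stated time of 48 h; a lower number here means a stronger inhibitor, a higher number a weaker inhibitor. Compound 2 `CCCC(C)Oc1ccc(C(=O)/C=C/c2c(/C=C/c3ccc(OC)cc3)cc(OC)cc2OC)cc1` gives 9.4 ug/mL. Compound 3 `COc1ccc(/C=C/c2cc(OC)cc(OC)c2/C=C/C(=O)c2ccc(N)cc2)cc1` gives 3.8 ug/mL.

Among these three numbers compound 1 holds the second highest. Its two neighbours both sit within the scatter of it: a 1.6-fold lower number from compound 1 to compound 3 (0.19 log units; within the scatter), and a 1.6-fold higher number from compound 1 to compound 2 (0.20 log units; within the scatter). Among the measured compounds shown here, only the pair of compounds 2 and 3 moves further, since a 2.5-fold lower number from compound 2 to compound 3 (0.39 log units; beyond the scatter).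

Compound 4 `COc1ccc(/C=C/c2cc(OC)cc(OC)c2/C=C/C(=O)c2ccccc2C)cc1` differs from compound 1 in one place: 2-methylphenyl in place of 3,4-dichlorophenyl on a carbonyl carbon. Both measured steps that swap the group on this carbonyl carbon, from compound 1 to compound 2 and from compound 1 to compound 3, stayed within the scatter. No step beyond the scatter is therefore expected in this assay for this exchange either. Compound 4 is estimated at 6 ug/mL, with a range from 3 ug/mL to 12 ug/mL, meaning an expected 1.0-fold higher number from compound 1 to compound 4 (0.01 log units; within the scatter).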

Compound 4, half-maximal inhibitory concentration: 5.9 ug/mL
For compound 4 the middle estimate is 1.0-fold (0.01 log units) above the measured one, within the range that was stated.
By their numbers in this assay, from the lowest: compounds 3, 1, 4 and 2 (each within the scatter of the next, the first and the last beyond it).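

With 2-methylphenyl on the carbonyl carbon, this assay gives three steps, all within the scatter: (no change at the digits printed from compound 1 to compound 4 (within the scatter)), (a 1.6-fold higher number from compound 3 to compound 4 (0.19 log units; within the scatter)) and (a 1.6-fold lower number from compound 2 to compound 4 (0.20 log units; within the scatter)). Among the compounds shown here, this all-carbon group thus sits within the scatter of both 4-aminophenyl and 4-(1-methylbutoxy)phenyl, the only two groups here that lie beyond the scatter of each other. Nothing available explains why these exchanges move the number so little.

Going by these compounds, whether a carboxylic acid on this phenyl ring, or a cyclohexyl group in its place, would leave the scatter remains open.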